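Fluorine for Azide: Cytotoxicity Expected to Stay Unmeasurably Low

The source may hold more compounds than are shown below. What is called first, only, known or untested is meant among the compounds shown, and "the series" means these compounds.

Three nucleoside analogues built on one sugar core have been tested in an ADME assay on PBMC cells (Homo sapiens) for cytotoxicity, read by trypan blue exclusion, with a stated time of 6 days; on this read-out lower numbers stand for higher toxicity in this test and higher numbers for lower toxicity in this test. Compound 1 `C=C(OCC)c1nc(N)nc2c1ncn2[C@@H]1O[C@H](CO)[C@@H](O)[C@@]1(C)O` carries an ethoxyvinyl group on its base; in this assay compound 1 reaches only the limit of the test, > 100000 nM. Compound 2 `C[C@@]1(O)[C@H](O)[C@@H](CO)O[C@H]1n1cnc2c(N)nc(N=[N+]=[N-])nc21` carries an azido group on its base; in this assay compound 2 likewise gives only a limit, > 100000 nM. Compound 3 `C[C@@]1(O)[C@H](O)[C@@H](CO)O[C@H]1n1cnc2c(N)nc(ONC(=O)OCc3ccccc3)nc21` bears a larger carbamate-containing substituent; in this assay compound 3 also stops at a limit, > 100000 nM. None of the three has received a numerical value: all of them sit at the limit of > 100000 nM in this assay, at which 3 of the 3 values shown sit, so compound 2 stands at the same limit as the other two, and no ordering among them can be drawn.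

Compound 4 `C[C@@]1(O)[C@H](O)[C@@H](CO)O[C@H]1n1cnc2c(N)nc(F)nc21` is the untested member. It differs from compound 2 by fluoro in place of azido on an aromatic carbon. Within the data shown here, no measured pair of compounds differing in one place exists, so there is no measured step to lean on. The starting point is that compound 2 itself sits only at > 100000 nM in this assay. The step from compound 2 to compound 4 is therefore expected to bring no shift beyond the scatter, a step that the limit leaves unreadable from compound 2 to compound 4. Compound 4 is accordingly expected to sit at about 150000 nM, most likely reported again as a limit, within a range of 50000 nM to 500000 nM.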

Compound 4, half-maximal cytotoxic concentration: > 100000 nM
Compound 4 ended at the assay's limit (the forecaster's own chance of this, stated with the estimate: 80%); the middle value is on the limit's open side.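

In this assay compound 4 gives > 100000 nM as a limit and not a number. Compound 2 stops at a limit too, so no step can be read for fluoro in place of azido between compound 2 and compound 4. The compounds shown leave open whether any change on the shared core shifts the result in this assay: the limit of > 100000 nM in this assay, at which 4 of the 4 values shown sit.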